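Alpha-cyclopropyl in place of alpha-ethoxy on the thiophene acid

The compounds below may be only part of what the source reports. "The series", "measured", "known", "first", "only" and "open" are said of these compounds alone.

Measured so far:
compound 1, `CCO[C@@H](CC(=O)O)c1ccc(OCc2cccc(-c3c(C)cccc3C)c2)s1`, 40100 nM in a functional assay on cells for agonist activity at Free fatty acid receptor 1 (Homo sapiens), read by calcium flux; on this read-out higher numbers stand for an effect only at larger amounts of compound and lower numbers for an effect already at smaller amounts
compound 2, `CC#C[C@@H](CC(=O)O)c1ccc(OCc2cccc(-c3c(C)cc(OCCCS(C)(=O)=O)cc3C)c2)s1`, 81 nM
compound 3, `O=C(O)CCc1ccc(OCc2cccc(-c3ccccc3C(F)(F)F)c2)s1`, 2710 nM

Compound 1 gives the highest number of the three in this assay. Compound 3, which carries no substituent on the chain bearing the acid and a different biaryl substituent, gives 2710 nM, clearly lower than compound 1. Compound 2, with a propynyl group on that chain and a further substituent on the outer ring, gives 81 nM, far lower still. Both neighbours differ from compound 1 in more than one place, so no single change can be read off them.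

Compound 4, `Cc1cccc(C)c1-c1cccc(COc2ccc(C(CC(=O)O)C3CC3)s2)c1`, is not yet measured. It differs from compound 1 as follows: 2-carboxy-1-cyclopropylethyl in place of 2-carboxy-1-ethoxyethyl on an aromatic carbon. The ether oxygen at that position is thus exchanged for a small carbocycle, with one hydrogen-bond acceptor fewer.

The two values from compound 2 and compound 3 suggest that a carbon substituent or none at that position goes with lower numbers than the ethoxy group. A downward step beyond the scatter is therefore expected from compound 1 to compound 4, a 13-fold lower number from compound 1 to compound 4 (1.13 log units; beyond the scatter). For compound 4 the expected value in this assay is 3000 nM, with a likely range from 500 nM to 15000 nM.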

Compound 4, half-maximal effective concentration: 3920 nM
Compound 4: middle estimate off by 1.3-fold (0.12 log units), on the low side; the range from low to high includes it.
By their numbers in this assay, from the lowest: compound 2; then compounds 3 and 4 (each within the scatter of the next); then compound 1.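

Within the data shown here, the first comparison that differs in one place only comes with this change in this assay and gives a 10-fold lower number from compound 1 to compound 4 (1.01 log units; beyond the scatter). With the rest of the structure held constant, replacing 2-carboxy-1-ethoxyethyl with 2-carboxy-1-cyclopropylethyl on this aromatic carbon moves the number beyond the scatter, with no change on the outer ring. Nothing available explains why the number moves.

Compound 4 is drawn without a defined stereocentre on this chain, unlike compound 1, so the part of the step that goes with that difference cannot be read. From the compounds shown here alone, it remains open whether a methyl, methoxy or open-chain propyl group at this carbon would give a number closer to compound 1 or compound 4, and whether the step keeps its size with the outer-ring substituent of compound 2.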